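The source may report more compounds than this note shows. Statements on the series, on what has been measured and on what is new or still open speak of the compounds shown alone.

Compound 1 `COc1ccc(-c2ccc(COC3CN(C#N)C3)cc2)cc1` gives 0.94 nM in an assay on isolated protein for inhibition of N-acylethanolamine-hydrolyzing acid amidase (Homo sapiens), read by fluorescence, with a stated time of 90 min; on this read-out higher numbers stand for weaker inhibition and lower numbers for stronger inhibition.
Compound 2 `N#CN1CC(OCc2ccc(-c3ccc(C(F)(F)F)cc3)cc2)C1` gives 1.6 nM in this assay.
Compound 3 `N#CN1CC(OCc2ccc(-c3ccc(F)cc3)cc2)C1` gives 0.68 nM in this assay.

Among these three, compound 3 has the lowest number in this assay; its gap to compound 1 lies within the usual scatter, whereas the step of a 2.4-fold lower number from compound 2 to compound 3 (0.37 log units; beyond the scatter) lies beyond it, so compound 3 can be set apart from compound 2 but not from compound 1. Compound 4 `N#CN1CC(OCc2ccc(-c3cccnc3)cc2)C1` has not yet been measured. It differs from compound 3 in one place: pyridin-3-yl in place of 4-fluorophenyl on an aromatic carbon. The three measured steps each exchange one substituent for another at the same place: a 1.7-fold higher number from compound 1 to compound 2 (0.23 log units; within the scatter), a 1.4-fold lower number from compound 1 to compound 3 (0.14 log units; within the scatter) and a 2.4-fold lower number from compound 2 to compound 3 (0.37 log units; beyond the scatter). None of them replaces the whole ring by pyridin-3-yl, so they bear only loosely on this change; what they do show is that variation at this place moved the numbers in this assay little, at most modestly. The step of a 1.8-fold higher number from compound 3 to compound 4 (0.25 log units; within the scatter) is therefore expected to be small and, if anything, upward. The estimate for compound 4 in this assay is 1.2 nM, with a range from 0.4 nM to 4 nM.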

Compound 4, half-maximal inhibitory concentration: 12 nM
Estimate against measurement, compound 4: 10-fold (1.00 log units) below; the whole stated range lies below it.
By their numbers in this assay, from the lowest: compounds 3, 1 and 2 (each within the scatter of the next, the first and the last beyond it); then compound 4.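

Pyridin-3-yl in place of 4-fluorophenyl brings an 18-fold higher number from compound 3 to compound 4 (1.25 log units; beyond the scatter) in this assay, so this position is far less forgiving than compounds 1, 2 and 3 alone suggested. Those compounds all kept the six-membered aromatic ring of carbon only and differed in its methoxy, trifluoromethyl or fluoro substituent, whereas this change puts a nitrogen into the ring, adds a hydrogen-bond acceptor and removes the fluoro group at once. Nothing measured here accounts for the size of this step.

The compounds shown do not separate the loss of the fluoro group from the arrival of the ring nitrogen, as an unsubstituted phenyl group would. They also leave open whether pyridin-2-yl or pyridin-4-yl would behave as pyridin-3-yl does.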